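Working notes: from 4-chlorobenzyl to 2-fluorobenzyl

The compounds below may be only part of what the source reports. "The series", "measured", "known", "first", "only" and "open" are said of these compounds alone.

Measured in a functional assay on Bel-7402 cells (Homo sapiens) for antiproliferative activity, read by MTT assay, with a stated time of 72 h; a higher number here means a weaker inhibitor, a lower number a stronger inhibitor:
- compound 1 `C=C1C(=O)O[C@H]2[C@H]1CC/C(Cn1cc(Cn3cc(F)c(=O)n(Cc4ccccc4)c3=O)nn1)=C\CC[C@@]1(C)O[C@@H]21`: 9160 nM
- compound 2 `C=C1C(=O)O[C@H]2[C@H]1CC/C(Cn1cc(Cn3cc(F)c(=O)n(Cc4ccc(F)cc4)c3=O)nn1)=C\CC[C@@]1(C)O[C@@H]21`: 4910 nM
- compound 3 `C=C1C(=O)O[C@H]2[C@H]1CC/C(COC(=O)Cn1cc(F)c(=O)n(Cc3ccc(Cl)cc3)c1=O)=C\CC[C@@]1(C)O[C@@H]21`: 2560 nM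

Compound 3 has the lowest number of the three, though its 2560 nM lies within the scatter of compound 2 at 4910 nM. Only its gap to compound 1 at 9160 nM goes beyond the scatter.

The next structure is compound 4 `C=C1C(=O)O[C@H]2[C@H]1CC/C(COC(=O)Cn1cc(F)c(=O)n(Cc3ccccc3F)c1=O)=C\CC[C@@]1(C)O[C@@H]21`. The change is 2-fluorophenyl in place of 4-chlorophenyl on a saturated chain carbon bound to an aromatic nitrogen, which puts 2-fluorophenyl in place of 4-chlorophenyl on a saturated chain carbon bound to an aromatic nitrogen.

For the measured compounds named here, only one measured step bears on this: a 1.9-fold lower number from compound 1 to compound 2 (0.27 log units; within the scatter), with fluoro in place of hydrogen on an aromatic carbon. It stayed within the scatter, and it does not replace a chloro group. The evidence is therefore thin, and no shift beyond the scatter is expected in this assay, with at most a slight drift to a higher number. The expected step is a 1.4-fold higher number from compound 3 to compound 4 (0.14 log units; within the scatter).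

For compound 4 the estimated value is 3500 nM, with an expected range of 1400 nM to 9000 nM.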

Compound 4, half-maximal inhibitory concentration: 3770 nM
Estimate against measurement, compound 4: 1.1-fold (0.03 log units) below; measured number inside the range.
By their numbers in this assay, from the lowest: compounds 3, 4, 2 and 1 (each within the scatter of the next, the first and the last beyond it).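

In this assay, 2-fluorophenyl in place of 4-chlorophenyl on a saturated chain carbon bound to an aromatic nitrogen gives a 1.5-fold higher number from compound 3 to compound 4 (0.17 log units; within the scatter). For the compounds shown here, this is the first step that takes away the chloro group rather than adding a fluoro group to an unsubstituted phenyl, and on the core of compound 3 the assay does not tell 4-chlorobenzyl and 2-fluorobenzyl apart. No measured evidence accompanies this result that could account for it.

With both the halogen and its place on the phenyl changing in one step, the compounds shown do not separate the two, and 2-chlorobenzyl on this core would bear on that question. Also open, on these data alone, is whether this place accepts a group of another kind, such as a carboxylic acid on the phenyl or a longer phenethyl chain.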